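The source may hold more compounds than are shown below. What is called first, only, known or untested is meant among the compounds shown, and "the series" means these compounds.

Of the compounds shown here, three sharing one core have been measured in an assay on CHO cells for agonist activity at 5-hydroxytryptamine receptor 1D (Homo sapiens), read by GTPgammaS binding; on this read-out higher numbers stand for an effect only at larger amounts of compound and lower numbers for an effect already at smaller amounts. Compound 1 `OCCC(NC1CCN(CCCc2c[nH]c3ccc(-n4cnnc4)cc23)CC1)c1ccccc1` gives 5.1 nM. Compound 2 `O[C@@H]1Cc2ccccc2[C@H]1NC1CCN(CCCc2c[nH]c3ccc(-n4cnnc4)cc23)CC1` gives 13 nM, and compound 3 `c1cc(CNC2CCN(CCCc3c[nH]c4ccc(-n5cnnc5)cc34)CC2)co1` gives 7.1 nM. Among these three numbers, the one for compound 1 is the lowest; its distance to compound 3 is a 1.4-fold higher number from compound 1 to compound 3 (0.14 log units; within the scatter), and its distance to compound 2 is a 2.5-fold higher number from compound 1 to compound 2 (0.41 log units; beyond the scatter).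

The next compound, compound 4 `C[C@H](NC1CCN(CCCc2c[nH]c3ccc(-n4cnnc4)cc23)CC1)c1ccccc1`, differs from compound 1 at the same amine nitrogen that was varied before: 1-phenylethyl in place of 3-hydroxy-1-phenylpropyl on an amine nitrogen. The phenyl ring is kept, while the 3-hydroxy-1-phenylpropyl side is shortened to 1-phenylethyl, which carries no hydrogen-bond donor or acceptor.

Both earlier steps away from the 3-hydroxy-1-phenylpropyl group bear on this change. Replacing it by 2-hydroxy-2,3-dihydro-1H-inden-1-yl gave a 2.5-fold higher number from compound 1 to compound 2 (0.41 log units; beyond the scatter), and replacing it by (furan-3-yl)methyl gave a 1.4-fold higher number from compound 1 to compound 3 (0.14 log units; within the scatter). Neither move shifted the number far, and both went toward higher numbers. A similar outcome is therefore expected for compound 4 in this assay: a 1.6-fold higher number from compound 1 to compound 4 (0.20 log units; within the scatter), a step that may well stay within the scatter. The estimate for compound 4 is 8 nM, with a range from 3 nM to 25 nM.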

Compound 4, half-maximal effective concentration: 12 nM
Beside the measured number, compound 4's estimate is 1.5-fold (0.18 log units) below it; low and high end bracket the measured number.
By their numbers in this assay, from the lowest: compounds 1, 3, 4 and 2 (each within the scatter of the next, the first and the last beyond it).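

In this assay the 1-phenylethyl group keeps the phenyl ring of compound 1 and gives up the end of the chain with its hydroxyl, and the result is a 2.4-fold higher number from compound 1 to compound 4 (0.37 log units; beyond the scatter) so the phenyl ring alone does not hold the number at the level of compound 1. The hydroxyl does not sort these compounds cleanly, though: compound 4 has none and compound 2 has one, yet they stand within the scatter of each other at a 1.1-fold lower number from compound 2 to compound 4 (0.03 log units; within the scatter) while compound 3 also has no hydroxyl and lies within the scatter of compound 4 at a 1.7-fold higher number from compound 3 to compound 4 (0.23 log units; within the scatter) and of compound 1 as well. Across these four groups on the amine nitrogen, the largest steps remain modest, so this position tolerates quite different groups in this assay.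

The chain was shortened and the hydroxyl lost in a single step, so a 1-phenylpropyl group, which keeps the chain without the hydroxyl, would be needed to tell these two changes apart. Nothing available here explains why the step from compound 1 to compound 4 has this size.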